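The source may report more compounds than this note shows. Statements on the series, on what has been measured and on what is new or still open speak of the compounds shown alone.

Of the compounds shown here, two of a shared core have been measured in an assay on isolated protein for binding affinity to Equilibrative nucleoside transporter 1 (Homo sapiens); a lower number here means a stronger inhibitor, a higher number a weaker inhibitor. Compound 1, `CCCCCNc1ncnc2c1ncn2[C@@H]1O[C@H](CO)[C@@H](O)[C@H]1O`, gives 13500 nM. Compound 2, `Cc1ccc([N+](=O)[O-])c(CNc2ncnc3c2ncn3[C@@H]2O[C@H](CO)[C@@H](O)[C@H]2O)c1`, gives 1290 nM. Going by the values given here, the one step between them, a 10-fold lower number from compound 1 to compound 2 (1.02 log units; beyond the scatter), shows that exchanging the butyl chain for an aromatic ring bearing a methyl group and a nitro group gave a much stronger inhibitor. Among the compounds with values here, on the numbers so far, compound 2 stands lowest of the two, with compound 1 as its only neighbour and a clearly higher number.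

Compound 3, `Cc1cc(CNc2ncnc3c2ncn3[C@@H]2O[C@H](CO)[C@@H](O)[C@H]2O)ccc1[N+](=O)[O-]`, is not yet measured. It keeps every atom of compound 2 but joins them differently: 3-methyl-4-nitrophenyl in place of 5-methyl-2-nitrophenyl on a saturated chain carbon bound to a nitrogen on an aromatic ring. Within the data shown here, no measured step bears directly on this change, since the only step known, from compound 1 to compound 2, introduced the aromatic ring itself rather than moving its groups around. With nothing to point one way or the other, the expected step for compound 3 is a 1.2-fold higher number from compound 2 to compound 3 (0.07 log units; within the scatter), that is, no step beyond the scatter. The estimate for compound 3 in this assay is therefore 1500 nM, with a range from 400 nM to 6000 nM.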

Compound 3, half-maximal inhibitory concentration: 87.1 nM
Compound 3: the middle estimate sits 17-fold (1.24 log units) above what was measured; the measured number lies below the stated range.
By their numbers in this assay, from the lowest: compound 3; then compound 2; then compound 1.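

In this assay, the shared core responds not only to which groups the ring carries but also to how they are arranged: with exactly the same atoms, 3-methyl-4-nitrophenyl in place of 5-methyl-2-nitrophenyl gives a 15-fold lower number from compound 2 to compound 3 (1.17 log units; beyond the scatter) and takes the number well beyond the scatter. Going by these compounds alone, the earlier compounds could not show this, as their one step only exchanged butyl for a substituted aromatic ring, so it said nothing about the arrangement of the groups on that ring. With the new arrangement, the full change from the butyl chain amounts to a 150-fold lower number from compound 1 to compound 3 (2.19 log units; beyond the scatter) and the ranking is now clear, but nothing available explains why moving these two groups alters the number so much.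

Both the methyl and the nitro group differ in their placement between compound 2 and compound 3, so the compounds shown cannot tell which of the two moves accounts for the step. Also open, as far as these compounds go, is what a plain phenyl ring would give, or a ring with an amine or a carboxylic acid in place of the nitro group.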